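The source may hold more compounds than are shown below. What is called first, only, known or untested is meant among the compounds shown, and "the series" means these compounds.

In an ADME assay on Huh-7 cells (Homo sapiens) for cytotoxicity, read by a luciferase reporter and MTT assay, with a stated time of 72 h (a higher number here means that more compound is tolerated, a lower number that less compound is tolerated), compound 1 `CCOc1cc(/C=N/NC(=O)C(C)Oc2ccc([N+](=O)[O-])cc2)ccc1OC(=O)c1ccc(Cl)cc1Cl` gives > 125000 nM, which is a limit and not a number. Compound 2 `O=C(COc1ccc([N+](=O)[O-])cc1)N/N=C/c1ccccc1OC(=O)c1sc2ccccc2c1Cl` gives > 125000 nM, also a limit, so its place on this scale is known only as that limit. Compound 3 `CC(Oc1ccc([N+](=O)[O-])cc1)C(=O)N/N=C/c1ccccc1OC(=O)c1sc2ccccc2c1Cl` differs from compound 2 by methyl in place of hydrogen on a saturated chain carbon bound to a carbonyl carbon and an oxygen on an aromatic ring, with methyl in place of hydrogen on a saturated chain carbon bound to a carbonyl carbon and an oxygen on an aromatic ring. Compound 1 also carries the 1-(4-nitrophenoxy)ethyl group. Given (the limit of > 125000 nM in this assay, at which 2 of the 2 values shown sit), the expected change is a number no higher from compound 2 to compound 3 (the limit leaves the size open), with no step beyond the usual scatter and no favoured direction. For compound 3 the estimated value is 125000 nM, with an expected range of 60000 nM to 250000 nM.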

Compound 3, half-maximal cytotoxic concentration: > 125000 nM
Compound 3: a limit, no number (the forecaster's own chance of this, stated with the estimate: 80%); the middle value sits exactly at the limit.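

In this assay, among these compounds, compound 2 and compound 3 each give only a limit, and no step between them can be read. The compounds shown leave open the concentration at which any of them becomes toxic to the cells, and whether methyl in place of hydrogen alters it.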